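A few compounds are considered here, and "the series" means these few. Any claim that something is new, unique, unknown or untested is made for them only; others in the source may bear on it.

Working notes on the series. Among the measured compounds shown here, compound 1 `Oc1ccc(-c2cc(-c3ccccc3)nc(-c3ccccc3Cl)c2)cc1` is the only member with a number in an ADME assay on HEK293 cells (Homo sapiens) for cytotoxicity, read by CCK-8 assay and cell counting, with a stated time of 2 days; a higher number here means a weaker inhibitor, a lower number a stronger inhibitor: compound 1 gives 3930 nM. Compound 2 `Oc1cccc(-c2cc(-c3ccncc3)nc(-c3cccc(Cl)c3)c2)c1` belongs to the same set, but in this assay compound 2 is recorded as "not determined" (no result reported), so it adds nothing to the numbers. Compound 1 therefore stands alone as the single point of reference, with no comparison above or below it.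

Compound 3 `Oc1ccc(-c2cc(-c3ccco3)nc(-c3ccccc3Cl)c2)cc1` is the next entry to be run in this assay. It differs from compound 1 in one place: furan-2-yl in place of phenyl on an aromatic carbon, in words furan-2-yl in place of phenyl on an aromatic carbon. For the measured compounds named here, no pair of measured compounds shows what such an exchange does here, so there is no basis for expecting a shift in either direction beyond the scatter. The step from compound 1 to compound 3 is expected to be a 1.0-fold higher number from compound 1 to compound 3 (0.01 log units; within the scatter). Compound 3 is estimated at 4000 nM, with a range from 1500 nM to 11000 nM.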

Compound 3, half-maximal inhibitory concentration: 4310 nM
Compound 3: middle estimate off by 1.1-fold (0.03 log units), on the low side; the range from low to high includes it.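

In this assay, among the compounds shown here, the first measured exchange, furan-2-yl in place of phenyl on the aromatic carbon next to the ring nitrogen, gives a 1.1-fold higher number from compound 1 to compound 3 (0.04 log units; within the scatter). At this position, then, a five-membered aromatic ring with 1 hetero atom and 1 hydrogen-bond acceptor reads the same as a six-membered aromatic ring of carbon only, although this rests on a single pair of compounds. Nothing available explains this result or connects it to any measured property of either group.

The compounds shown leave open whether an amine, a carboxylic acid or a longer chain on this same carbon would move the number beyond the scatter. They also leave open whether any exchange at the 2-chlorophenyl group or the 4-hydroxyphenyl group would do so.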